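The source may hold more compounds than are shown below. What is called first, only, known or untested is meant among the compounds shown, and "the series" means these compounds.

Measured in an ADME assay on blood (Rattus norvegicus) for metabolic stability; on this read-out higher numbers stand for a longer-lived compound and lower numbers for a shorter-lived compound:
- compound 1 `OC[C@@H]1CC[C@H](n2cnc3c(F)ncnc32)O1`: 0.0583 h
- compound 2 `OC[C@@H]1CC[C@H](n2cnc3c(Cl)ncnc32)O1`: 4.5 h

Of the two, compound 2 stands higher, at 4.5 h. Compound 3 `OC[C@@H]1CC[C@H](n2cnc3c(Br)ncnc32)O1` differs from it in one place: bromo in place of chloro on an aromatic carbon. Among the compounds with values here, only one measured step bears on this change, the large 77-fold higher number from compound 1 to compound 2 (1.89 log units; beyond the scatter), made at the same place. A single step sets no trend for bromo, so in this assay a slight fall, not beyond the scatter, is expected. The expected change is a 1.3-fold lower number from compound 2 to compound 3 (0.11 log units; within the scatter). For compound 3 the estimate is 3.5 h, with an expected range of 1.2 h to 9 h.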

Compound 3, half-life: 4.67 h
For compound 3 the middle estimate is 1.3-fold (0.13 log units) below the measured one, within the range that was stated.
By their numbers in this assay, from the lowest: compound 1; then compounds 2 and 3 (each within the scatter of the next).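

In this assay, bromo and chloro on this aromatic carbon cannot be told apart (a 1.0-fold higher number from compound 2 to compound 3 (0.02 log units; within the scatter)). The large difference seen between chloro and fluoro returns with bromo (an 80-fold higher number from compound 1 to compound 3 (1.90 log units; beyond the scatter)), so among these three compounds, fluoro alone stands apart at this position. Nothing at hand explains why. The compounds shown leave open whether the half-life depends on having a halogen here at all. An amine or a methoxy group on this aromatic carbon might give a number closer to compound 1 or to compound 2.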